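The source may report more compounds than this note shows. Statements on the series, on what has been measured and on what is new or still open speak of the compounds shown alone.

Measured so far:
- Compound 1, `Brc1ccc(NCc2nc3ccc(Br)cc3[nH]2)cc1`, gives 20% in a functional assay on the whole organism (strain albino) for inhibition, with Rattus norvegicus as the target, read by paw edema, with a stated time of 60 min, at a dose of 100 mg/kg by the oral route; a lower number here means less inhibition, a higher number more inhibition at the dose given (going by the name of the read-out).
- Compound 2, `COc1ccc(NCc2nc3ccccc3[nH]2)cc1`, gives 26.6%.
- Compound 3, `O=[N+]([O-])c1ccc2nc(CNc3ccc(Br)cc3)[nH]c2c1`, gives 20%.

Compound 3 stands level with compound 1 at the digits shown, and together they are the lowest of the three numbers. Compound 2 lies a little higher, but that gap is within the scatter, so no order can be read from it. Within the data shown here, the only one-place step among the measured compounds is no change at the digits printed from compound 1 to compound 3 (within the scatter), which exchanges one group for another on an aromatic carbon without moving the number.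

Compound 4, `Brc1ccc(NCc2nc3ccccc3[nH]2)cc1`, is not yet measured. It differs from compound 3 in one place: hydrogen in place of nitro on an aromatic carbon. Among the measured compounds shown here, no measured pair shows what removing the group at that position does on its own; compound 2 carries hydrogen there but also differs on the other ring, so its value and that of compound 3 can only be set side by side, where they fall within the scatter of each other. Because no change at the digits printed from compound 1 to compound 3 (within the scatter) was flat, the expected step is a number 2 percentage points higher from compound 3 to compound 4 (within the scatter), which is no more than the scatter in either direction. Compound 4 is therefore estimated at 22%, within a range from 12% to 32%.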

Compound 4, a percentage reported as inhibition, in the whole organism at one dose (the size of the read-out at that dose, not a potency): 13.3%
The estimate for compound 4 lay 8.7 percentage points above the measured number, and the stated range covers the measured number.
By their numbers in this assay, from the lowest: compounds 4, 1, 3 and 2 (each within the scatter of the next, the first and the last beyond it).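

In this assay, hydrogen in place of nitro gives a number 6.7 percentage points lower from compound 3 to compound 4 (within the scatter), and hydrogen in place of bromo at the same carbon gives a number 6.7 percentage points lower from compound 1 to compound 4 (within the scatter). Hydrogen, nitro and bromo on this aromatic carbon therefore cannot be told apart in this measurement, whereas the earlier compounds could compare only nitro with bromo and had no version with the position left bare. Among these compounds, compound 4 also provides the first step beyond the usual scatter, a modest one made by a change on the other aromatic ring: with bromo in place of methoxy there, the result is a number 13.3 percentage points lower from compound 2 to compound 4 (beyond the scatter).

Nothing available explains why the change on that ring moves the number, or why the changes on the fused ring system do not move it beyond the scatter. The compounds shown leave open whether an amine or a carboxylic acid on the fused ring system would shift the reading, and whether methoxy would still stand apart from bromo on the other ring in a compound that also carries nitro on the core.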